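Swapping the benzylamino urea terminus for a fused azole

This account rests on a few compounds, and the source may have more. Where it says the series, first, only, none or still open, it means among the compounds named here.

The three measured compounds share the core shown in compound 1 `CCN(CC)C(=O)NCCCC(C)Nc1cc(OC)cc2cccnc12`, a urea joined through a short chain to a methoxy-bearing bicyclic amine. Compound 1, carrying a diethylamino group on the carbonyl carbon, gives 207000 nM in a functional assay on L1210 cells (Mus musculus), read by MTT assay, with a stated time of 72 h; a lower number here means a stronger inhibitor, a higher number a weaker inhibitor. Compound 2 `COc1cc(NC(C)CCCNC(=O)NCc2ccccc2)c2ncccc2c1` gives 22000 nM and stands second highest of the three numbers; compound 3 `COc1cc(NC(C)CCCNC(=O)N(C2CCCCC2)C2CCCCC2)c2ncccc2c1` gives 15000 nM, a value within the scatter of compound 2, so the two cannot be ordered. Compound 1 is the outlier: there is a 9.4-fold lower number from compound 1 to compound 2 (0.97 log units; beyond the scatter).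

Compound 4 `COc1cc(NC(C)CCCNC(=O)n2nnc3ccccc32)c2ncccc2c1` is the unmeasured member. It differs from compound 2 in one place: a group of 9 heavy atoms (6 carbon, 3 nitrogen; one five-membered aromatic ring with 3 hetero atoms, one six-membered aromatic ring of carbon only) in place of a group of 8 heavy atoms (7 carbon, 1 nitrogen; one six-membered aromatic ring of carbon only), on a carbonyl carbon. For the measured compounds named here, the only measured step that bears on this position is the one from compound 1 to compound 2, which was modest and moved to a lower number; the pair of compound 2 and compound 3 shows that a second exchange at the same carbonyl carbon left the number within the scatter. Because the step of a 9.4-fold lower number from compound 1 to compound 2 (0.97 log units; beyond the scatter) is the lone precedent and the change here swaps one aromatic-containing group for another, compound 4 is expected to land near compound 2, with an expected step of a 1.4-fold lower number from compound 2 to compound 4 (0.14 log units; within the scatter). Compound 4 is estimated at 16000 nM, with a range from 4000 nM to 60000 nM.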

Compound 4, half-maximal inhibitory concentration: 125000 nM
For compound 4 the middle estimate is 7.8-fold (0.89 log units) below the measured one; the measured number lies above the stated range.
By their numbers in this assay, from the lowest: compounds 3 and 2 (each within the scatter of the next); then compounds 4 and 1 (each within the scatter of the next).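

The change at this carbonyl carbon is not neutral: in this assay there is a 5.7-fold higher number from compound 2 to compound 4 (0.75 log units; beyond the scatter), so an aromatic ring in the entering group does not by itself hold the number at the level of compound 2. There is also a 1.7-fold lower number from compound 1 to compound 4 (0.22 log units; within the scatter), which leaves compound 4 level with the diethylamino compound, and so the drop in the number seen with benzylamino does not extend to every aromatic-containing group on this carbonyl carbon. The exchange also replaces 1 hydrogen-bond donor and 0 hydrogen-bond acceptors with 0 hydrogen-bond donors and 3 hydrogen-bond acceptors, but this difference comes together with the change of ring, and nothing available accounts for the shift in the number.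

The compounds shown leave open whether the loss follows the missing amide hydrogen, the ring nitrogens of the entering group, or its direct attachment through a ring nitrogen to the carbonyl carbon. A benzylamino group carrying a methyl on its nitrogen, or an indole joined through its ring nitrogen, would each separate some of these features.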